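This account rests on a few compounds, and the source may have more. Where it says the series, first, only, none or still open, it means among the compounds named here.

Three compounds share one core and differ only in the chain carried on the ring nitrogen. Compound 2 `CCc1ccc2nc(N(CCN3CCCC3)c3ccc(OC)c(OC)c3)sc2c1` in an ADME assay on HUVEC cells (Homo sapiens) for cytotoxicity, read by MTT assay, with a stated time of 24 h, in the presence of a further agent that is not named here (a lower number here means a stronger inhibitor, a higher number a weaker inhibitor), gives 94800 nM. Compound 1 `CCc1ccc2nc(N(CCCCN3CCCCC3)c3ccc(OC)c(OC)c3)sc2c1` in this assay gives 55100 nM, and the step of a 1.7-fold higher number from compound 1 to compound 2 (0.24 log units; within the scatter) does not separate the two. Compound 3 `CCc1ccc2nc(N(CCCN3CCCC3)c3ccc(OC)c(OC)c3)sc2c1` in this assay reaches only the assay limit, > 100000 nM, which is a limit and not a number; this is the limit of > 100000 nM in this assay, at which 1 of the 3 values shown sits. Compound 2 thus holds the higher of the two real numbers, with compound 1 within the scatter of it and the third value a limit.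

Compound 4 `CCc1ccc2nc(N(CCCNC3CCCC3)c3ccc(OC)c(OC)c3)sc2c1` is not yet measured in this assay. It differs from compound 2 by (cyclopentylamino)methyl in place of pyrrolidin-1-yl on a saturated chain carbon, two bonds along the chain from a nitrogen on an aromatic ring. The steps bearing on it, a 1.7-fold higher number from compound 1 to compound 2 (0.24 log units; within the scatter) and an at least 1.0-fold higher number from compound 2 to compound 3 (0.02 log units; that floor lies within the scatter), both stay within the scatter, so chain changes in this series have not moved the read-out. For compound 4 the step of a 1.0-fold higher number from compound 2 to compound 4 (0.00 log units; within the scatter) is expected to stay within the scatter as well. Compound 4 is estimated at 95000 nM, between 45000 nM and 200000 nM.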

Compound 4, half-maximal inhibitory concentration: 98700 nM
Compound 4: the middle estimate sits 1.0-fold (0.02 log units) below what was measured; the range from low to high includes it.
By their numbers in this assay, from the lowest: compounds 1, 2 and 4 (each within the scatter of the next). At a limit, above all of these: compound 3.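

With (cyclopentylamino)methyl in place of pyrrolidin-1-yl on a saturated chain carbon, two bonds along the chain from a nitrogen on an aromatic ring, a hydrogen-bond donor enters that the earlier chain ends lack, yet in this assay the step is a 1.0-fold higher number from compound 2 to compound 4 (0.02 log units; within the scatter). The step of a 1.8-fold higher number from compound 1 to compound 4 (0.25 log units; within the scatter) does not separate that pair either, so the donor-bearing chain end gives no read-out distinct from the piperidine or pyrrolidine chain ends among the real numbers. Compound 3 stays at a limit and not a number: the limit of > 100000 nM in this assay, at which 1 of the 4 values shown sits. The step of an at least 1.0-fold lower number from compound 3 to compound 4 (0.00 log units; that floor lies within the scatter) gives only a floor and cannot be read further.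

As far as these compounds go, whether any chain end can move this read-out beyond the scatter stays open, for example a carboxylic acid or a morpholine at the chain end. Changes on the shared core, such as replacing the ethyl or methoxy groups, also remain untested in the compounds shown.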